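Oxan-2-yl in Place of Cyclopentyl: What to Expect

This account rests on a few compounds, and the source may have more. Where it says the series, first, only, none or still open, it means among the compounds named here.

The measured compounds, with their numbers in a functional assay, read by fluorescence and spectrophotometry, with a stated time of 1 h; on this read-out higher numbers stand for an effect only at larger amounts of compound and lower numbers for an effect already at smaller amounts:
compound 1, `O=S(=O)(/C=C/c1ccc(O)c(O)c1)CC1CCCC1`, gives 9400 nM;
compound 2, `CCCCCCCCCCCS(=O)(=O)/C=C/c1ccc(O)c(O)c1`, gives 11400 nM;
compound 3, `C=CCCCCCCCS(=O)(=O)/C=C/c1ccc(O)c(O)c1`, gives 6900 nM.

All three numbers lie within the usual scatter of one another. Compound 1 has the nearest neighbour in compound 2 and the furthest in compound 3, yet neither gap exceeds that scatter, so no ordering among them can be claimed. Within the data shown here, the only single-point step measured so far is a 1.7-fold lower number from compound 2 to compound 3 (0.22 log units; within the scatter), and it sits far from the sulfonyl sulfur.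

Compound 4, `O=S(=O)(/C=C/c1ccc(O)c(O)c1)CC1CCCCO1`, differs from compound 1 by oxan-2-yl in place of cyclopentyl on a saturated chain carbon bound to a sulfonyl sulfur. Among the measured compounds shown here, no measured step touches this position, so the closest guide is the general flatness of the three numbers and the small size of the step from compound 2 to compound 3. On that basis compound 4 is expected to stay close to compound 1, and the step of a 1.0-fold lower number from compound 1 to compound 4 (0.02 log units; within the scatter) is estimated to lie within the scatter. The estimate for compound 4 in this assay is 9000 nM, with a range from 4000 nM to 20000 nM.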

Compound 4, half-maximal effective concentration: 10800 nM
Compound 4: middle estimate off by 1.2-fold (0.08 log units), on the low side; the range from low to high includes it.
By their numbers in this assay, from the lowest: compounds 3, 1, 4 and 2 (each within the scatter of the next).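

In this assay, among these compounds, this is the first measured step at this position: a 1.1-fold higher number from compound 1 to compound 4 (0.06 log units; within the scatter), which lies within the scatter. A six-membered ring with a hetero atom and a hydrogen-bond acceptor can therefore take the place of a five-membered ring of carbon only on a saturated chain carbon bound to a sulfonyl sulfur, with no difference that can be claimed on this read-out. No supporting measurement is available that would bear on this result.

The compounds shown leave open whether any group at this place can move the number beyond the scatter, for example an amine or a carboxylic acid in place of oxan-2-yl. They also leave open whether the match between oxan-2-yl and cyclopentyl would hold on any other read-out.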